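Adding a hydroxy group to compound 1

The source may report more compounds than this note shows. Statements on the series, on what has been measured and on what is new or still open speak of the compounds shown alone.

In a toxicity assay on cells (Macrophage, Homo sapiens) for inhibition, read by MTT assay (a higher number here means a weaker inhibitor, a lower number a stronger inhibitor), compound 1 (`CN(C)CCCNc1nc(-c2ccccc2)nc2ccccc12`) returns > 100000 nM which is a limit of the assay and not a number (the limit of > 100000 nM in this assay, at which 1 of the 3 values shown sits). In this assay compound 2 (`COc1ccc(-c2nc(NCCN(C)C)c3ccccc3n2)cc1`) gives 57000 nM and compound 3 (`COc1ccc(-c2nc(NCCCN3CCN(C)CC3)c3ccccc3n2)cc1`) gives 53000 nM as measured values. Within the data shown here, the only measured step (a 1.1-fold lower number from compound 2 to compound 3 (0.03 log units; within the scatter)) is a change on the chain and does not test the aromatic ring. Compound 4 (`CN(C)CCCNc1nc(-c2ccc(O)cc2)nc2ccccc12`) turns phenyl into 4-hydroxyphenyl, with hydroxy in place of hydrogen on an aromatic carbon. Among the measured compounds shown here, with no measured step for this change, the expected step in this assay (an at least 1.1-fold lower number from compound 1 to compound 4 (0.04 log units; that floor lies within the scatter)) is none beyond the scatter and has no firm direction. The value estimated for compound 4 is 90000 nM in a range of 35000 nM to 200000 nM and a limit of the assay is again expected as a possible outcome.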

Compound 4, half-maximal inhibitory concentration: 65000 nM
Compound 4: middle estimate off by 1.4-fold (0.14 log units), on the high side; the range from low to high includes it.
By their numbers in this assay, from the lowest: compounds 3, 2 and 4 (each within the scatter of the next). At a limit, above all of these: compound 1.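

The change on the aromatic ring, which the earlier step along the chain did not test, reads in this assay as an at least 1.5-fold lower number from compound 1 to compound 4 (0.18 log units; that floor lies within the scatter). Hydroxy on the aromatic carbon para to a large group thus still gives a measured number, but the floor of this step does not establish a change beyond the scatter. Compound 1 stands at a limit of the assay and not at a number, so the true size of the step stays unknown: the limit of > 100000 nM in this assay, at which 1 of the 4 values shown sits.

From the compounds shown here alone, whether an amine or a carboxylic acid at this place would read any differently stays open. So does the effect of a longer chain on the hydroxy oxygen.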